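The compounds below may be only part of what the source reports. "The series", "measured", "known", "first", "only" and "open" are said of these compounds alone.

Measured so far in a toxicity assay on MT2 cells (Homo sapiens) for cytotoxicity, read by XTT assay, with a stated time of 4 days; on this read-out lower numbers stand for higher toxicity in this test and higher numbers for lower toxicity in this test:
compound 1 `Cc1ccc(-c2ccc(C(=O)N[C@@H](c3nc(C)c(CCO)s3)[C@@H]3CCCCN3)[nH]2)cc1F`: 21200 nM
compound 2 `Cc1nc([C@H](NC(=O)c2ccc(-c3ccc(Cl)c(F)c3)[nH]2)[C@@H]2CCCCN2)sc1CCO`: 16800 nM
compound 3 `Cc1ccc(-c2ccc(C(=O)N[C@@H](c3nc(C)c(CCCO)s3)[C@@H]3CCCCN3)[nH]2)cc1F`: 20600 nM

Compound 3, at 20600 nM, lies within the scatter of both compound 1 and compound 2, so these three numbers show no order in this assay. Next in line is compound 4 `Cc1nc([C@H](NC(=O)c2ccc(-c3ccc(Cl)c(F)c3)[nH]2)[C@@H]2CCCCN2)sc1CCCO`, not yet measured. The change from compound 3 is chloro in place of methyl on an aromatic carbon. In words, 3-fluoro-4-methylphenyl becomes 4-chloro-3-fluorophenyl, with chloro in place of methyl on an aromatic carbon, ortho to a fluoro group and para to a large group.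

The same exchange has been measured once, as a 1.3-fold lower number from compound 1 to compound 2 (0.10 log units; within the scatter), which is within the scatter. The other measured step, a 1.0-fold lower number from compound 1 to compound 3 (0.01 log units; within the scatter), is the hydroxymethyl in place of hydroxy on the saturated chain, and it is also within the scatter. Among the measured compounds shown here, compound 4 carries both changes, and no measured compound yet tests them together. With only these two steps as evidence, no shift beyond the scatter is expected in this assay. The estimate is a 1.2-fold lower number from compound 3 to compound 4 (0.10 log units; within the scatter), expected to stay within the scatter. For compound 4 the expected value is 16500 nM, with an estimated range of 10000 nM to 27000 nM.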

Compound 4, half-maximal cytotoxic concentration: 12600 nM
Beside the measured number, compound 4's estimate is 1.3-fold (0.12 log units) above it; low and high end bracket the measured number.
By their numbers in this assay, from the lowest: compounds 4, 2, 3 and 1 (each within the scatter of the next).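

In this assay, the exchange of 3-fluoro-4-methylphenyl for 4-chloro-3-fluorophenyl now has a second reading on a second core, a 1.6-fold lower number from compound 3 to compound 4 (0.21 log units; within the scatter), and the two readings agree: the same change on two cores in this assay, a 1.3-fold lower number (0.10 log units; within the scatter) from compound 1 to compound 2 and a 1.6-fold lower number (0.21 log units; within the scatter) from compound 3 to compound 4, 1.3-fold (0.11 log units) apart, within the scatter of two such steps. The step from hydroxy to hydroxymethyl on the saturated chain also gains a second reading, now on the chloro-bearing core, a 1.3-fold lower number from compound 2 to compound 4 (0.12 log units; within the scatter), and these two readings agree as well: the same change on two cores in this assay, a 1.0-fold lower number (0.01 log units; within the scatter) from compound 1 to compound 3 and a 1.3-fold lower number (0.12 log units; within the scatter) from compound 2 to compound 4, 1.3-fold (0.11 log units) apart, within the scatter of two such steps. All four steps in this small square stay within the scatter, so neither change moves the number beyond the scatter on either core, and the square gives no sign that one change alters the size of the other.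

As far as these compounds go, it remains open whether another group on this aromatic carbon, such as trifluoromethyl or methoxy, would give a step beyond the scatter in this assay. The same question stands for other chain ends, such as an amine, a carboxylic acid or a longer chain, and the compounds shown give no reading of how either change behaves on a core with a different ring at the pyrrole-free end of the molecule.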